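Swapping the Benzyl Ring of Compound 3 for Pyridine

The compounds below may be only part of what the source reports. "The series", "measured", "known", "first", "only" and "open" are said of these compounds alone.

The measured compounds, all tested in an assay on isolated protein for binding affinity to Equilibrative nucleoside transporter 1 (Homo sapiens); a lower number here means a stronger inhibitor, a higher number a weaker inhibitor:

Compound 1 `O=[N+]([O-])c1ccc2c(c1)CN(c1ncnc3c1ncn3[C@@H]1O[C@H](CO)[C@@H](O)[C@H]1O)CC2`: 5.5 nM
Compound 2 `O=[N+]([O-])c1ccc2c(c1)CN(c1ncnc3c1nc1n3[C@@H]3O[C@H](CO1)[C@@H](O)[C@H]3O)CC2`: 331 nM
Compound 3 `Nc1nc(SCc2ccc(Br)cc2)c2ncn([C@@H]3O[C@H](CO)[C@@H](O)[C@H]3O)c2n1`: 813 nM

Compound 3 carries the highest number of the three, so it is the weakest inhibitor in this set. Its nearest neighbour is compound 2, whose value sits a little beyond the usual scatter of repeated measurements; compound 1 lies far below both, with a gap that no scatter could account for.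

Compound 4 `Nc1nc(SCc2ccccn2)c2ncn([C@@H]3O[C@H](CO)[C@@H](O)[C@H]3O)c2n1` is the unmeasured partner of compound 3. The two differ in one place:

pyridin-2-yl in place of 4-bromophenyl on a saturated chain carbon bound to a sulfur

Within the data shown here, no two measured compounds differ in this way, so there is no measured step to lean on. The three values do show that changes on the side chain attached to the shared core move the number substantially. For compound 4 the expectation is a modest weakening, a step from compound 3 of a 2.2-fold higher number from compound 3 to compound 4 (0.35 log units; beyond the scatter), with a wide margin of doubt. Compound 4 is therefore estimated at 1800 nM, within a range from 500 nM to 6500 nM.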

Compound 4, half-maximal inhibitory concentration: 34700 nM
For compound 4 the middle estimate is 19-fold (1.29 log units) below the measured one; the whole stated range lies below it.
By their numbers in this assay, from the lowest: compound 1; then compound 2; then compound 3; then compound 4.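

In this assay the group on a saturated chain carbon bound to a sulfur turns out to matter greatly: pyridin-2-yl in place of 4-bromophenyl gives a 43-fold higher number from compound 3 to compound 4 (1.63 log units; beyond the scatter) and makes compound 4 the weakest inhibitor of the four. Among these compounds, the earlier compounds differed from one another in more than one place, so this is the first single change that can be read, and it shows that exchanging these two similarly sized aromatic rings is far from neutral at this position. Nothing available accounts for the size of this step.

The compounds shown leave open whether the step follows the loss of the bromine or the arrival of the ring nitrogen. A plain phenyl on the same carbon would separate the two, and a pyridin-4-yl would test whether the place of that nitrogen matters.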